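A few compounds are considered here, and "the series" means these few. Any claim that something is new, unique, unknown or untested is made for them only; others in the source may bear on it.

For the measured compounds named here, compound 1 `CC(=O)Nc1c(C(O)(C(F)(F)F)C(F)(F)F)ccc2ccccc12` gives 18 nM in an assay on LtK cells with ATP-sensitive inward rectifier potassium channel 11 (Homo sapiens) as the target (a higher number here means that more compound is needed for the effect, a lower number that less compound is needed), the lowest of the three numbers measured so far. Compound 2 `O=C(Nc1c(C(O)(C(F)(F)F)C(F)(F)F)ccc2ccccc12)c1ccccc1Cl` gives 2040 nM in this assay, and compound 3 `O=C(Nc1c(C(O)(C(F)(F)F)C(F)(F)F)ccc2ccccc12)c1cccc(Cl)c1` gives 98 nM. Compound 4 `O=C(Nc1c(C(O)(C(F)(F)F)C(F)(F)F)ccc2ccccc12)c1cccc(Br)c1` has not yet been measured; it differs from compound 1 in one place: 3-bromophenyl in place of methyl on a carbonyl carbon. Going by the values given here, two measured steps bear on this change, since both replace the same methyl with a substituted phenyl ring. The step of a 110-fold higher number from compound 1 to compound 2 (2.05 log units; beyond the scatter) was large, whereas the step of a 5.4-fold higher number from compound 1 to compound 3 (0.74 log units; beyond the scatter) was modest, and the step of a 21-fold lower number from compound 2 to compound 3 (1.32 log units; beyond the scatter) shows how far these two rings lie apart. The 3-bromophenyl of compound 4 stands closest to the 3-chlorophenyl of compound 3, so a modest rise in this assay is expected for compound 4, of about the size seen for compound 3, because of a 5.4-fold higher number from compound 1 to compound 3 (0.74 log units; beyond the scatter). Compound 4 is therefore expected to give 110 nM in this assay, within a range from 40 nM to 320 nM. That expectation corresponds to a step of a 6.1-fold higher number from compound 1 to compound 4 (0.79 log units; beyond the scatter).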

Compound 4, half-maximal effective concentration: 80 nM
Estimate against measurement, compound 4: 1.4-fold (0.14 log units) above, and the stated range covers the measured number.
By their numbers in this assay, from the lowest: compound 1; then compounds 4 and 3 (each within the scatter of the next); then compound 2.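

In this assay, bromo in place of chloro on an aromatic carbon makes no difference beyond the scatter, a 1.2-fold lower number from compound 3 to compound 4 (0.09 log units; within the scatter), so the two halogens are not told apart on this 3-substituted phenyl ring. The cost of replacing the methyl with a 3-halophenyl group now holds for a second compound, a 4.4-fold higher number from compound 1 to compound 4 (0.65 log units; beyond the scatter), while the gap to the 2-chlorophenyl ring stays large, a 26-fold lower number from compound 2 to compound 4 (1.41 log units; beyond the scatter), which, with the step between compound 3 and compound 4 so small, points to where the halogen sits on the ring rather than which halogen it is. Nothing available explains these differences.

The compounds shown leave open how unsubstituted phenyl, 3-methoxyphenyl or a longer alkyl chain on the carbonyl carbon would compare with compound 1. On these data alone, it also remains open whether 2-bromophenyl would give a number as high as that of compound 2.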